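The source may report more compounds than this note shows. Statements on the series, on what has been measured and on what is new or still open speak of the compounds shown alone.

Series notes, sphingosine 1-phosphate receptor 2 antagonists.

Of the compounds shown here, two carry numbers so far. Compound 1 `COc1cc(OC)c(NC(=O)Cc2nn(CC(=O)O)c(=O)c3ccccc23)cc1Cl` is the weaker of the pair: in a functional assay on CHO cells for antagonist activity at sphingosine 1-phosphate receptor 2 (Homo sapiens), read by calcium flux (a higher number here means a weaker inhibitor, a lower number a stronger inhibitor), compound 1 gives 186 nM. Compound 2 `O=C(O)Cn1nc(Cc2cn3cc(OCC4CC4)c(Cl)cc3n2)c2ccccc2c1=O`, which replaces the amide-linked aryl portion with a different bicyclic arrangement on the shared core, gives 9 nM in this assay. The gap between the two is well beyond the scatter, so compound 1 stands at the high end of the numbers in hand. Among the measured compounds shown here, no single-point step between measured compounds exists, so nothing yet shows how small edits on the aryl ring of compound 1 move the readout.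

Compound 3 `COc1ccc(Cl)cc1NC(=O)Cc1nn(CC(=O)O)c(=O)c2ccccc12` is the next compound to be measured. It differs from compound 1 in one place: hydrogen in place of methoxy on an aromatic carbon. The ring keeps its chloro group and one methoxy group; only the second methoxy is lost.

For the measured compounds named here, with no measured step of this kind to lean on, the expectation for compound 3 is a modest shift, if any: a 1.6-fold higher number from compound 1 to compound 3 (0.21 log units; within the scatter) is the estimated step, pointing toward slightly weaker inhibition but possibly within the scatter. Compound 3 is expected to give about 300 nM in this assay, with a likely range of 100 nM to 900 nM.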

Compound 3, half-maximal inhibitory concentration in the sphingosine 1-phosphate receptor 2 assay: > 1790 nM
Compound 3: a limit, no number; the forecaster's own chance of this, stated with the estimate: 5%; middle value at least 5.9-fold (0.77 log units) from the limit.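

Among the compounds shown here, this position on the aryl ring of compound 1 turns out to matter far more than the earlier compounds could show: in the sphingosine 1-phosphate receptor 2 assay, hydrogen in place of methoxy, at the carbon ortho to a chloro group and para to a large group, gives an at least 9.6-fold higher number from compound 1 to compound 3 (0.98 log units; beyond the scatter). The reading for compound 3 is a limit of the assay and not a number, so the step has a floor but no fixed size: the limit of > 1790 nM in the sphingosine 1-phosphate receptor 2 assay, at which 1 of the 3 values shown sits.

In a physicochemical assay for lipophilicity, at pH 7.4 (a higher number here means a more lipophilic compound, a lower number a more polar compound), compound 1 gives 1.64 and compound 3 gives 1.9, two values within the scatter of each other, so the step in the sphingosine 1-phosphate receptor 2 assay has no counterpart beyond the scatter in this second read-out.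

The compounds shown do not say whether the methoxy itself is needed at this carbon or whether another group, such as ethoxy, hydroxy or fluoro, would hold the number of compound 1. They also leave open how the chloro group and the remaining methoxy group contribute, since neither has yet been changed on its own.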